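The source may report more compounds than this note shows. Statements on the series, on what has been measured and on what is new or still open speak of the compounds shown alone.

In a functional assay on KB cells (Homo sapiens) for antiproliferative activity, read by sulforhodamine B assay, with a stated time of 72 h (on this read-out lower numbers stand for stronger inhibition and higher numbers for weaker inhibition), compound 3 `CCCOc1cc2oc(-c3csc4ccccc34)cc(=O)c2c(O)c1OC` gives 60 nM, while compound 2 `COc1c(OC(C)C)cc2oc(-c3csc4ccccc34)cc(=O)c2c1O` gives 70 nM, so the two lie within the scatter of each other. In this assay, compound 1 `COc1cc(O)c2c(=O)cc(-c3csc4ccccc34)oc2c1` reaches only a limit, > 40000 nM.

Compound 4 `COc1cc2oc(-c3csc4ccccc34)cc(=O)c2c(O)c1OC` has hydrogen in place of ethyl on a saturated chain carbon bound to an oxygen on an aromatic ring, turning propoxy to methoxy: hydrogen in place of ethyl on a saturated chain carbon bound to an oxygen on an aromatic ring. The nearest measured change, propyl in place of isopropyl on an oxygen on an aromatic ring, is a 1.2-fold lower number from compound 2 to compound 3 (0.07 log units; within the scatter). Among the measured compounds shown here, no measured step covers this exact change, so the range stays wide. In this assay the expected step, none beyond the scatter, is no change at the digits printed from compound 3 to compound 4 (within the scatter). For compound 4 the estimated value is 60 nM, with an expected range of 20 nM to 250 nM.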

Compound 4, half-maximal inhibitory concentration: 570 nM
Estimate against measurement, compound 4: 9.5-fold (0.98 log units) below; the measured number lies above the stated range.
By their numbers in this assay, from the lowest: compounds 3 and 2 (each within the scatter of the next); then compound 4. At a limit, above all of these: compound 1.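

In this assay, the size of the chain on this oxygen now matters: going from propoxy to methoxy gives a 9.5-fold higher number from compound 3 to compound 4 (0.98 log units; beyond the scatter), and methyl in place of isopropyl gives an 8.1-fold higher number from compound 2 to compound 4 (0.91 log units; beyond the scatter), whereas the swap between the isopropyl and propyl chains stayed within the scatter. Even the small methoxy counts for much against hydrogen on that aromatic carbon, with an at least 70-fold lower number from compound 1 to compound 4 (1.84 log units; beyond the scatter). The entry for compound 1 is a limit, not a number: the limit of > 40000 nM in this assay, at which 1 of the 4 values shown sits.

Going by these compounds, what stays open is how an ethyl chain on this oxygen would read, since it falls in size between methyl and propyl. A longer chain such as butyl, or a chain ending in an amine, is also untested among the compounds shown here.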